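The source may hold more compounds than are shown below. What is called first, only, known or untested is meant among the compounds shown, and "the series" means these compounds.

The measured compounds:
Compound 1, `CC(C)C(c1ccc(-c2ccc3cccc(F)c3c2)[nH]c1=O)C1NC(=O)NC1=O`: in a functional assay on CHO cells for antagonist activity at prostaglandin E2 receptor EP3 subtype (Homo sapiens), read by cAMP accumulation, with a stated time of 30 min (a lower number here means a stronger inhibitor, a higher number a weaker inhibitor), compound 1 gives 320 nM.
Compound 2, `CC(C)C(c1ccc(-c2ccc3cccc(F)c3c2)[nH]c1=O)C1SC(=O)NC1=O`: compound 2 gives 110 nM.
Compound 3, `CC(C)C(CC1NC(=O)NC1=O)c1ccc(-c2ccc3cccc(F)c3c2)[nH]c1=O`: compound 3 gives 31 nM.

Compound 3 stands lowest of the three numbers in this assay. The step of a 3.5-fold lower number from compound 2 to compound 3 (0.55 log units; beyond the scatter) and the step of a 10-fold lower number from compound 1 to compound 3 (1.01 log units; beyond the scatter) both lie beyond the scatter, so compound 3 is the strongest inhibitor of the three measured.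

Compound 4, `CC(C)C(/C=C1/C(=O)NC(=O)N1C)c1ccc(-c2ccc3cccc(F)c3c2)[nH]c1=O`, has not yet been measured. It differs from compound 3 by a group of 9 heavy atoms (5 carbon, 2 nitrogen, 2 oxygen; one five-membered non-aromatic ring with 2 hetero atoms) in place of a group of 8 heavy atoms (4 carbon, 2 nitrogen, 2 oxygen; one five-membered non-aromatic ring with 2 hetero atoms), on a saturated chain carbon bound to an aromatic carbon and a saturated chain carbon. The group that enters carries one double bond more outside aromatic rings and one hydrogen-bond donor less than the group that leaves.

All three measured steps alter this same position: a 2.9-fold lower number from compound 1 to compound 2 (0.46 log units; beyond the scatter), a 10-fold lower number from compound 1 to compound 3 (1.01 log units; beyond the scatter) and a 3.5-fold lower number from compound 2 to compound 3 (0.55 log units; beyond the scatter). They show that changes at this position move the number by modest to large amounts, and that the (2,5-dioxoimidazolidin-4-yl)methyl group gave the lowest number. Among the measured compounds shown here, none of them removes a hydrogen-bond donor or adds a double bond, so no measured step speaks directly to the change in compound 4. For the measured compounds named here, since every change at this position so far moved the number beyond the scatter, and compound 3 already holds the lowest value, a step upward beyond the scatter is expected. The estimate for compound 4 is 100 nM, with a range from 25 nM to 400 nM, meaning an expected step of a 3.2-fold higher number from compound 3 to compound 4 (0.51 log units; beyond the scatter).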

Compound 4, half-maximal inhibitory concentration: 11 nM
Compound 4: middle estimate off by 9.1-fold (0.96 log units), on the high side; measured number below the stated range.
By their numbers in this assay, from the lowest: compound 4; then compound 3; then compound 2; then compound 1.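

Among the compounds shown here, at the saturated chain carbon bound to an aromatic carbon and a saturated chain carbon, compound 4 brings the first change that removes a hydrogen-bond donor and adds a double bond outside aromatic rings, and the outcome is a 2.8-fold lower number from compound 3 to compound 4 (0.45 log units; beyond the scatter). The same group also compares well with the other two measured groups, giving a 10-fold lower number from compound 2 to compound 4 (1.00 log units; beyond the scatter) and a 29-fold lower number from compound 1 to compound 4 (1.46 log units; beyond the scatter), so compound 4 is the strongest inhibitor of the four in this assay. Having one hydrogen-bond donor fewer in this group therefore did not cost activity in this comparison, and the (2,5-dioxoimidazolidin-4-yl)methyl group no longer marks the lowest number at this place.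

No measurement shown here offers a reason for the lower number of compound 4. From the compounds shown here alone, the extra heavy atom, the added double bond and the lost hydrogen-bond donor all change together in this one step, so their separate shares remain unresolved, and it also remains open how a carboxylic acid or a longer chain would behave at this place.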